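The compounds below may be only part of what the source reports. "The series", "measured", "known", "first", "only" and "open" are said of these compounds alone.

Of the compounds shown here, two have numbers so far in an ADME assay on Caco-2 cells (Homo sapiens) for permeability; on this read-out higher numbers stand for higher permeability and lower numbers for lower permeability. Compound 1 `CN(C)Cc1ccccc1-c1ccc(N2CCc3c(C(F)(F)F)nn(-c4ccc5onc(N)c5c4)c3C2=O)c(F)c1` gives 8.9 10^-6 cm/s, and compound 2 `Nc1noc2ccc(-n3nc(C(F)(F)F)c4c3C(=O)N(c3ccc(-c5ccccc5CN5CCC(O)CC5)cc3)CC4)cc12` gives 0.4 10^-6 cm/s. Compound 2 is therefore the lower of the two, and its gap to compound 1 lies beyond the usual scatter of repeated measurements.

Compound 3 `CN(C)Cc1ccccc1-c1ccc(N2CCc3c(C(F)(F)F)nn(-c4ccc5onc(N)c5c4)c3C2=O)cc1` has not yet been measured. Compared with compound 2, it has dimethylamino in place of 4-hydroxypiperidin-1-yl on a saturated chain carbon bound to an aromatic carbon. Within the data shown here, no measured pair of compounds isolates this change, so any expectation for it remains tentative. Among the measured compounds shown here, the only guide is that dimethylamino is also present in compound 1, which stands at 8.9 10^-6 cm/s.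

On that basis, a rise beyond the scatter is expected in this assay, with the estimated step being an 18-fold higher number from compound 2 to compound 3 (1.24 log units; beyond the scatter). Compound 3 is expected to give about 7 10^-6 cm/s, with an estimated range from 2.5 10^-6 cm/s to 18 10^-6 cm/s.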

Compound 3, apparent permeability: 4.7 10^-6 cm/s
Compound 3: the middle estimate sits 1.5-fold (0.17 log units) above what was measured; the range from low to high includes it.
By their numbers in this assay, from the lowest: compound 2; then compounds 3 and 1 (each within the scatter of the next).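

In this assay, compound 1 and compound 2 differ in two places, so their gap could not be assigned to either one, whereas dimethylamino in place of 4-hydroxypiperidin-1-yl on a saturated chain carbon bound to an aromatic carbon now stands alone as a single change and gives a 12-fold higher number from compound 2 to compound 3 (1.07 log units; beyond the scatter) in this series. The other place can also be read on its own: hydrogen in place of fluoro on an aromatic carbon gives a 1.9-fold lower number from compound 1 to compound 3 (0.28 log units; within the scatter), so this read-out does not separate compound 1 from compound 3, and the large step belongs to the change of the amine group. Nothing available explains why either step has the size it does.

The change removes a ring and a hydroxyl group together, so the step alone cannot say which of them matters; a plain piperidin-1-yl or an open-chain amine carrying a hydroxyl group on the same carbon would separate the two. From the compounds shown here alone, whether hydrogen and fluoro would also stand this close with 4-hydroxypiperidin-1-yl in place, and how chloro or methyl at that aromatic carbon would read, remains open.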